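A few compounds are considered here, and "the series" means these few. Any claim that something is new, unique, unknown or untested is made for them only; others in the source may bear on it.

Of the compounds shown here, two sharing one core have so far been measured in a functional assay on A549 cells (Homo sapiens) for antiproliferative activity, read by MTT assay, with a stated time of 72 h; on this read-out higher numbers stand for weaker inhibition and lower numbers for stronger inhibition. In this test, compound 1 `CC(C)(C)OC(=O)N1CCN(C(=S)Sc2ccc(C(C)(C)C)cc2)CC1`, with a tert-butyl group on its aromatic ring, gives 769 nM, and compound 2 `CC(C)(C)OC(=O)N1CCN(C(=S)Sc2ccc(Cl)cc2)CC1`, with chloro at that place, gives 1070 nM. Among the measured compounds shown here, compound 2 therefore stands level with compound 1, its only neighbour on these numbers, and the two cannot be ranked. The next analogue, compound 3 `CC(C)(C)OC(=O)N1CCN(C(=S)Sc2ccc(Br)cc2)CC1`, has bromo in place of chloro on an aromatic carbon, para to a large group: bromo in place of chloro on an aromatic carbon. For the measured compounds named here, only one measured step bears on this change, the exchange at the same place of tert-butyl for chloro. That step, a 1.4-fold higher number from compound 1 to compound 2 (0.14 log units; within the scatter), stayed within the scatter, although it replaced a whole tert-butyl group. One halogen now replaces another, so no step beyond the scatter is expected in this assay. The expected change, a 1.1-fold lower number from compound 2 to compound 3 (0.05 log units; within the scatter), is an estimate and lies within the scatter. For compound 3 the estimated value is 950 nM, with an expected range of 500 nM to 1800 nM.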

Compound 3, half-maximal inhibitory concentration: 1820 nM
Compound 3: the middle estimate sits 1.9-fold (0.28 log units) below what was measured, and the stated range ends below it.
By their numbers in this assay, from the lowest: compounds 1, 2 and 3 (each within the scatter of the next, the first and the last beyond it).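

The exchange of chloro for bromo on the aromatic carbon (a 1.7-fold higher number from compound 2 to compound 3 (0.23 log units; within the scatter)) stayed within the scatter in this assay, so the 4-chlorophenyl and 4-bromophenyl compounds cannot be ranked, and this second step at the position again fails to separate two neighbouring compounds. Among the compounds shown here, the position is nevertheless not wholly indifferent to what it carries: the comparison of the tert-butyl and bromo compounds (a 2.4-fold higher number from compound 1 to compound 3 (0.37 log units; beyond the scatter)) gives the first step at this place beyond the scatter, although a modest one, with compound 2 within the scatter of both of the others. The data at hand offer no measurement that would account for this small separation between tert-butyl and bromo.

The three compounds cover only tert-butyl, chloro and bromo at a single place on the ring, so they leave open whether an amine, a carboxylic acid or a methoxy group there would shift the number further than these groups do. They also leave open whether the modest separation between tert-butyl and bromo would persist with a different group on the far side of the shared core.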